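The source may hold more compounds than are shown below. What is called first, only, known or untested is meant among the compounds shown, and "the series" means these compounds.

Two compounds have been measured in an ADME assay on microsomes from liver (Homo sapiens) for pharmacokinetics; on this read-out higher numbers stand for fast clearance and lower numbers for slow clearance:

- compound 1 `C[C@@H]1CN(c2nc(-c3cnn(C)c3)ncc2C#N)CCN1C(=O)C1(C)CC1`: < 16 mL/min/kg
- compound 2 `Cn1cc(-c2ncc(C#N)c(N3C[C@@H]4C[C@H]3CN4c3cccc(F)c3)n2)cn1`: 76 mL/min/kg

Compound 1 yields no exact number, only a limit: the limit of < 16 mL/min/kg in this assay, at which 1 of the 2 values shown sits. Compound 2, by contrast, gives a measured number of 76 mL/min/kg.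

The next compound to be tested is compound 3 `CC1CC1C(=O)N1CCN(c2nc(-c3cnn(C)c3)ncc2C#N)C[C@H]1C`, which has the same atoms as compound 1, joined differently: 2-methylcyclopropyl in place of 1-methylcyclopropyl on a carbonyl carbon. In words, it carries 2-methylcyclopropyl in place of 1-methylcyclopropyl on a carbonyl carbon, and the rest of the structure is unchanged. Among the compounds with values here, no measured pair shows what this swap does in this assay, so any forecast is uncertain. A small move toward faster clearance is expected, with the estimated step being an at least 1.1-fold higher number from compound 1 to compound 3 (0.05 log units; that floor lies within the scatter). That step may well not exceed the scatter. For compound 3, the estimated clearance is 18 mL/min/kg, with an expected range of 9 mL/min/kg to 40 mL/min/kg.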

Compound 3, clearance: < 16 mL/min/kg
Compound 3: no number, only a limit; the forecaster's own chance of this, stated with the estimate: 45%; middle value at least 1.1-fold (0.05 log units) from the limit.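

Compound 1 and compound 3 both stand at a limit in this assay and give no exact number, so no step between them can be read: the limit of < 16 mL/min/kg in this assay, at which 2 of the 3 values shown sit.

The compounds shown leave open the exact clearance of compound 1 and compound 3, and whether this swap of methylcyclopropyl groups changes it at all.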